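A few compounds are considered here, and "the series" means these few. Any claim that something is new, unique, unknown or untested is made for them only; others in the source may bear on it.

Compound 1 `CCn1c(C(=O)N[C@@H](C)C(=O)OC)ccc1C(CC)(CC)c1ccc(OCS(=O)(=O)c2ccccc2)c(C)c1`: 17900 nM
Compound 2 `CCn1c(C(=O)NCCN)ccc1C(CC)(CC)c1ccc(OCS(=O)(=O)c2ccccc2)c(C)c1`: 6430 nM
Compound 3 `CCn1c(C(=O)N[C@H](C)CO)ccc1C(CC)(CC)c1ccc(OCS(=O)(=O)c2ccccc2)c(C)c1`: 10000 nM

In a functional assay on BXPC-3 cells (Homo sapiens) for antiproliferative activity, read by MTT assay, with a stated time of 24 h (a higher number here means a weaker inhibitor, a lower number a stronger inhibitor), compound 1 gives the highest of the three numbers; compound 3 sits nearest, with a 1.8-fold lower number from compound 1 to compound 3 (0.25 log units; within the scatter), and compound 2 furthest, with a 2.8-fold lower number from compound 1 to compound 2 (0.44 log units; beyond the scatter). Compound 4 `CCn1c(C(=O)N[C@@H](CO)C(C)C)ccc1C(CC)(CC)c1ccc(OCS(=O)(=O)c2ccccc2)c(C)c1` differs from compound 1 in one place: 1-(hydroxymethyl)-2-methylpropyl in place of 1-(methoxycarbonyl)ethyl on an amide-type nitrogen. The step from compound 1 to compound 3 is the one that bears most directly on it, since it also brings a hydroxymethyl onto the amide-type nitrogen, and that step stayed within the scatter; the step to compound 2 was modest. Compound 4 is therefore expected to show at most a small decrease, a 1.5-fold lower number from compound 1 to compound 4 (0.17 log units; within the scatter), giving an estimate of 12000 nM with a range from 5000 nM to 28000 nM.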

Compound 4, half-maximal inhibitory concentration: 13200 nM
Beside the measured number, compound 4's estimate is 1.1-fold (0.04 log units) below it; low and high end bracket the measured number.
By their numbers in this assay, from the lowest: compounds 2, 3, 4 and 1 (each within the scatter of the next, the first and the last beyond it).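

In this assay, the amide-type nitrogen accepts 1-(hydroxymethyl)-2-methylpropyl in place of 1-(methoxycarbonyl)ethyl with no readable change (a 1.4-fold lower number from compound 1 to compound 4 (0.13 log units; within the scatter)), and isopropyl in place of methyl on the saturated chain carbon also stays within the scatter (a 1.3-fold higher number from compound 3 to compound 4 (0.12 log units; within the scatter)). Only the 2-aminoethyl of compound 2 stands apart, in a modest step (a 2.1-fold higher number from compound 2 to compound 4 (0.31 log units; beyond the scatter)). No measurement offered here accounts for these steps. Still open, on these data alone, is whether a longer chain ending in an amine, or a carboxylic acid in place of the methyl ester, would move the number further.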